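Inverting one stereocentre: from compound 3 to compound 4

This account rests on a few compounds, and the source may have more. Where it says the series, first, only, none or still open, it means among the compounds named here.

Values in an ADME assay on MT4 cells (Homo sapiens) for cytotoxicity, read by MTT assay, with a stated time of 5 days; a higher number here means that more compound is tolerated, a lower number that less compound is tolerated:
- compound 1 `Cc1cc(C)cc(S(=O)(=O)c2c(C(=O)N[C@@H]3CCNC3)[nH]c3ccc(Cl)cc23)c1`: 37300 nM
- compound 2 `Cc1cc(C)cc(S(=O)(=O)c2c(C(=O)N[C@@H]3CCN(Cc4ccccc4C#N)C3)[nH]c3ccc(Cl)cc23)c1`: >= 186000 nM, a limit of the assay and not a number
- compound 3 `Cc1cc(C)cc(S(=O)(=O)c2c(C(=O)N[C@@H]3CCN(CC(N)=O)C3)[nH]c3ccc(Cl)cc23)c1`: 31000 nM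

Compound 3 sits level with compound 1, as the measured change is a 1.2-fold lower number from compound 1 to compound 3 (0.08 log units; within the scatter). It stands well apart from compound 2, with an at least 6.0-fold lower number from compound 2 to compound 3 (0.77 log units; beyond the scatter).

Compound 4 `Cc1cc(C)cc(S(=O)(=O)c2c(C(=O)N[C@H]3CCN(CC(N)=O)C3)[nH]c3ccc(Cl)cc23)c1` changes only the spatial arrangement: the two compounds have the same atoms and bonds and differ only in configuration as drawn: 1 of 1 stereo elements differ; a stereocentre at a saturated ring carbon is drawn R in compound 3 and S in compound 4. Among the measured compounds shown here, no measured step tests such a change. The steps of a 1.2-fold lower number from compound 1 to compound 3 (0.08 log units; within the scatter) and an at least 4.9-fold higher number from compound 1 to compound 2 (0.69 log units; beyond the scatter) both concern a new group on the ring amine nitrogen, so they offer only loose guidance. No change beyond the scatter is therefore expected in this assay, though with wide uncertainty. The expected change is a 1.1-fold higher number from compound 3 to compound 4 (0.03 log units; within the scatter). For compound 4 the estimated value is 33000 nM, with an expected range from 15000 nM to 80000 nM.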

Compound 4, half-maximal cytotoxic concentration: 28100 nM
For compound 4 the middle estimate is 1.2-fold (0.07 log units) above the measured one; measured number inside the range.
By their numbers in this assay, from the lowest: compounds 4, 3 and 1 (each within the scatter of the next). At a limit, above all of these: compound 2.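

In this assay, inverting the stereocentre at the saturated ring carbon gives a 1.1-fold lower number from compound 3 to compound 4 (0.04 log units; within the scatter), so for this pair the drawn configuration makes no difference that can be read. Compound 4 also stays level with the parent amine lacking the carbamoylmethyl group, with a 1.3-fold lower number from compound 1 to compound 4 (0.12 log units; within the scatter).

As far as these compounds go, compound 2 gives >= 186000 nM, a limit of the assay and not a number, so it remains open whether inverting the same stereocentre would also change nothing with a 2-cyanobenzyl group on the ring nitrogen. From the compounds shown here alone, it is equally open whether the result would hold with a carboxylic acid in place of the carbamoyl group.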